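Amide nitrogen variation and writhing inhibition; outlook for compound 4

A few compounds are considered here, and "the series" means these few. Any claim that something is new, unique, unknown or untested is made for them only; others in the source may bear on it.

Compound 1 `O=C(Oc1ccc(-c2ccc(F)cc2F)cc1C(=O)Nc1ccccc1)c1ccccc1`, compound 2 `Cc1ccccc1NC(=O)c1cc(-c2ccc(F)cc2F)ccc1OC(=O)c1ccccc1` and compound 3 `CCN(CC)C(=O)c1cc(-c2ccc(F)cc2F)ccc1OC(=O)c1ccccc1` share one core and differ only in the group attached to the amide carbonyl carbon. In a functional assay on the whole organism (strain Kunming) for inhibition, with Mus musculus as the target, in the writhing test, at a dose of 40 mg/kg by the oral route (a lower number here means less inhibition, a higher number more inhibition at the dose given (going by the name of the read-out)), compound 1 gives 5.57%, compound 2 gives 20.8% and compound 3 gives 0%. Compound 3 holds the smallest of the three numbers; its difference from compound 1 is within the scatter, that from compound 2 beyond it.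

Compound 4 `CN1CCN(NC(=O)c2cc(-c3ccc(F)cc3F)ccc2OC(=O)c2ccccc2)CC1` has not been measured. Its change from compound 3 is (4-methylpiperazin-1-yl)amino in place of diethylamino on a carbonyl carbon. Among the measured compounds shown here, two measured steps bear on this, both at the same carbonyl carbon: a number 5.6 percentage points lower from compound 1 to compound 3 (within the scatter) and a number 20.8 percentage points lower from compound 2 to compound 3 (beyond the scatter). Replacing the group on the amide nitrogen has so far moved this assay by a modest amount at most, and the larger move was the one involving the (2-methylphenyl)amino group, which compound 4 does not carry. A step of a number 8 percentage points higher from compound 3 to compound 4 (within the scatter) is therefore expected, within or at the edge of the scatter. Compound 4 is estimated to give 8%, with a range from 0% to 25%.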

Compound 4, a percentage reported as inhibition, in the whole organism at one dose (the size of the read-out at that dose, not a potency): 88.3%
The estimate for compound 4 lay 80.3 percentage points below the measured number; measured number above the stated range.
By their numbers in this assay, from the lowest: compounds 3 and 1 (each within the scatter of the next); then compound 2; then compound 4.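

At this carbonyl carbon, the group on the amide nitrogen can move this assay far more than the earlier modest steps showed: the change to (4-methylpiperazin-1-yl)amino gives a number 88.3 percentage points higher from compound 3 to compound 4 (beyond the scatter). On the amide-type nitrogen, 4-methylpiperazin-1-yl also stands well clear of both aryl groups, with a number 67.5 percentage points higher from compound 2 to compound 4 (beyond the scatter) and a number 82.7 percentage points higher from compound 1 to compound 4 (beyond the scatter). Compound 1 and compound 2 also carry the amide hydrogen, so that hydrogen alone does not separate them from compound 4.

Open, going by these compounds, is whether a piperidin-1-yl or morpholin-4-yl ring on the amide-type nitrogen, or an open-chain dimethylamino group there, would keep this level, and so whether the ring or its methylated nitrogen matters. No measurement offered here bears on why this step is so large.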